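This account rests on a few compounds, and the source may have more. Where it says the series, first, only, none or still open, it means among the compounds named here.

Three compounds share one core and differ in the side groups. Compound 1 `CCCC(C)n1c(CC)nc2c(-c3ccc(Cl)cc3Cl)nccc21` gives 3 nM in an assay for binding affinity to Corticotropin releasing factor receptor (Rattus norvegicus); on this read-out higher numbers stand for weaker inhibition and lower numbers for stronger inhibition. Compound 3 `CCCC(C)n1c(CC)nc2c(-c3ccc(Cl)cc3C)nccc21` gives 9.1 nM in this assay, and the step of a 3.0-fold higher number from compound 1 to compound 3 (0.48 log units; beyond the scatter) involves a methyl in place of chloro on an aromatic carbon. Compound 2 `CCc1nc2c(-c3ccc(C(F)(F)F)cc3Cl)nccc2n1C(CC)CC` gives 5.4 nM in this assay, a number that sits within the usual scatter of both compound 1 and compound 3, so no order among them can be claimed.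

Compound 4 `CCc1nc2c(-c3ccc(C(F)(F)F)cc3Cl)nccc2n1C(CC)C1CC1` is not yet measured. It differs from compound 2 by cyclopropyl in place of ethyl on a saturated chain carbon bound to an aromatic nitrogen and a saturated chain carbon. No measured step among these compounds touches that chain carbon; the only measured step concerns the aromatic ring. With nothing to go on beyond compound 2 itself, the expected step of a 1.1-fold lower number from compound 2 to compound 4 (0.03 log units; within the scatter) is one that stays within the scatter. Compound 4 is therefore estimated at 5 nM in this assay, with a range from 2 nM to 15 nM.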

Compound 4, inhibition constant: 2.9 nM
Compound 4: the middle estimate sits 1.7-fold (0.24 log units) above what was measured; the range from low to high includes it.
By their numbers in this assay, from the lowest: compounds 4, 1, 2 and 3 (each within the scatter of the next, the first and the last beyond it).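

On the saturated chain carbon bound to an aromatic nitrogen and a saturated chain carbon, cyclopropyl in place of ethyl gives a 1.9-fold lower number from compound 2 to compound 4 (0.27 log units; within the scatter) in this assay. Among the compounds shown here, this is the first measured change at this chain carbon, and it shows that going from pentan-3-yl to 1-cyclopropylpropyl, which brings in a ring of carbon only, is tolerated here without a change that can be told from the scatter. Nothing shown here offers an explanation for this result.

As far as these compounds go, it remains open whether a larger ring such as cyclohexyl, a longer chain such as butyl, or an ether such as methoxymethyl at this carbon would stay in the same range. Also open, from the compounds shown here alone, is whether cyclopropyl would be tolerated equally with chloro in place of trifluoromethyl on the aromatic ring.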